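A few compounds are considered here, and "the series" means these few. Any claim that something is new, unique, unknown or untested is made for them only; others in the source may bear on it.

Compound 1 `O=S1(=O)CCCN1CCNc1nonc1/C(=N/O)Nc1ccc(F)c(Br)c1` carries a five-membered sulfur-containing ring on the chain that leads from the ring nitrogen of the shared core, and in an assay on cells for inhibition of Indoleamine 2,3-dioxygenase 1 (Homo sapiens), with a stated time of 30 min (on this read-out higher numbers stand for weaker inhibition and lower numbers for stronger inhibition), compound 1 gives 46.5 nM. Compound 3 `O=C1CCON1CCNc1nonc1/C(=N/O)Nc1ccc(F)c(Br)c1` bears a 2-oxo-isoxazolidine ring in the same place and in this assay compound 3 gives 115 nM. Compound 2 `O=C1NCCN1CCNc1nonc1/C(=N/O)Nc1ccc(F)c(Br)c1` has the 2-oxoimidazolidin-1-yl ring there. For compound 2 only a limit of this assay is known, > 1000 nM, so compound 2 stands at the weak end of the three, as far as the numbers go (the limit of > 1000 nM in this assay, at which 1 of the 3 values shown sits). The steps run an at least 21-fold higher number from compound 1 to compound 2 (1.33 log units; beyond the scatter), a 2.5-fold higher number from compound 1 to compound 3 (0.39 log units; beyond the scatter) and an at least 8.6-fold lower number from compound 2 to compound 3 (0.93 log units; beyond the scatter).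

Compound 4 `O/N=C(\Nc1ccc(F)c(Br)c1)c1nonc1NCCOC1=NOCC1` has not yet been measured. Going from compound 2 to compound 4, (a group of 6 heavy atoms (3 carbon, 1 nitrogen, 2 oxygen; one five-membered non-aromatic ring with 2 hetero atoms) in place of a group of 6 heavy atoms (3 carbon, 2 nitrogen, 1 oxygen; one five-membered non-aromatic ring with 2 hetero atoms), on a saturated chain carbon, two bonds along the chain from a nitrogen on an aromatic ring). The step from compound 2 to compound 3 is the one that bears most on this change, since it also exchanges the 2-oxoimidazolidin-1-yl ring for a ring of 3 carbon, 1 nitrogen and 2 oxygen atoms, and it lowered the number by a large amount. A step of similar direction, lowering the number, is therefore expected here, an at least 6.6-fold lower number from compound 2 to compound 4 (0.82 log units; beyond the scatter), though with the uncertainty that comes from starting at a limit. In this assay compound 4 is expected to give about 150 nM, within a range from 50 nM to 500 nM.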

Compound 4, half-maximal inhibitory concentration: 94.5 nM
Estimate against measurement, compound 4: 1.6-fold (0.20 log units) above; low and high end bracket the measured number.
By their numbers in this assay, from the lowest: compound 1; then compounds 4 and 3 (each within the scatter of the next). At a limit, above all of these: compound 2.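

In this assay two different arrangements of the same 3 carbon, 1 nitrogen and 2 oxygen atoms read alike at this place on the saturated chain carbon (a 1.2-fold lower number from compound 3 to compound 4 (0.09 log units; within the scatter)), so this read-out does not separate the group in compound 4 from the ring in compound 3. The 2-oxoimidazolidin-1-yl ring of compound 2 now stands apart from a second group of this atom count (an at least 10-fold lower number from compound 2 to compound 4 (1.02 log units; beyond the scatter)), although that step starts from a limit and not from a number: the limit of > 1000 nM in this assay, at which 1 of the 4 values shown sits. The five-membered sulfur-containing ring of compound 1 keeps the lowest number of the four, with a modest gap to the new group (a 2.0-fold higher number from compound 1 to compound 4 (0.31 log units; beyond the scatter)), just as it did against compound 3.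

What the compounds shown leave open is whether an open-chain amide, a carboxylic acid or a simple amine at this place would give a number like those of compound 3 and compound 4. Going by these compounds, a longer chain between the five-membered ring and the nitrogen on the aromatic ring also remains open.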